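A few compounds are considered here, and "the series" means these few. Any claim that something is new, unique, unknown or untested is made for them only; others in the source may bear on it.

Measured compounds:
- Compound 1, `CC1CC1c1cc(NC(=O)Cn2nnc(-c3ccccc3)n2)n(C2CCCCC2)n1`: in an assay on HEK293 cells for activation of Kir3.1/Kir3.2 (Homo sapiens), read by thallium flux (a higher number here means a larger maximal response, a lower number a smaller maximal response), compound 1 gives 78%.
- Compound 2, `Cc1cc(NC(=O)Cn2nnc(-c3ccccn3)n2)n(C2CCCCC2)n1`: in this assay compound 2 gives 81%.

Compound 2 has the higher of the two numbers, but the gap to the value of compound 1 is within the scatter of this kind of measurement, so the two compounds cannot be placed in an order on these data. Both share the same core, and they differ in the group attached to the five-membered aromatic ring with 4 nitrogen.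

Compound 3, `Cc1cc(NC(=O)Cn2nnc(C3CC3)n2)n(C2CCCCC2)n1`, is the next compound and has not yet been measured in this assay. It is derived from compound 2 by a single change: cyclopropyl in place of pyridin-2-yl on an aromatic carbon. For the measured compounds named here, no comparable step among the measured compounds is available to show how an aromatic group at this position compares with a small non-aromatic ring, so any expectation rests on the two values above alone. A small to moderate decrease in the largest response is expected, with the step of a number 11 percentage points lower from compound 2 to compound 3 (beyond the scatter) likely reaching beyond the scatter but with wide uncertainty. For compound 3 the expected value in this assay is 70%, estimated between 45% and 92%.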

Compound 3, largest response reached (Emax), in percent of the reference or control that the assay uses: > 68%
Compound 3: only a limit was reported (the forecaster's own chance of this, stated with the estimate: 5%); the middle value does not contradict the limit.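

In this assay compound 3 is reported only as a limit, > 68%. For the compounds shown here, no step from compound 2 to compound 3 can be read from this result. The compounds shown leave open how large the maximal response of compound 3 is, and whether cyclopropyl in place of pyridin-2-yl changes that response at all.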